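A few compounds are considered here, and "the series" means these few. Any claim that something is new, unique, unknown or untested is made for them only; others in the source may bear on it.

Working notes on the series. The measured set so far comprises compound 1 `COc1cc(NC(=O)Nc2cc(Nc3ccc(C(C)(C)C)cc3)ncn2)cc(OC)c1` and compound 2 `COc1cc(Br)ccc1Nc1cc(NC(=O)Nc2c(Cl)cccc2Cl)ncn1`, both run in a functional assay on NCI-H520 cells (Homo sapiens) for inhibition, read by MTT assay, with a stated time of 48 h, tested at 10 uM; on this read-out higher numbers stand for more inhibition at the one concentration tested (going by the name of the read-out) and lower numbers for less inhibition. In this assay compound 1 gives 17.5%, and compound 2 gives 29.1%. Compound 1 thus stands lowest of the two numbers in hand; its nearest neighbour is compound 2, whose number lies higher by a margin beyond the usual scatter. For the measured compounds named here, no pair of measured compounds differs in one place only, so no single-change step can be read from the measured set.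

The untested member, compound 3 `COc1cc(NC(=O)Nc2cc(Nc3ccc(OC)c(C)c3)ncn2)cc(OC)c1`, differs from compound 1 in one place: 4-methoxy-3-methylphenyl in place of 4-(tert-butyl)phenyl on a nitrogen on an aromatic ring. Going by the values given here, nothing measured here bears on this exchange, so there is no step to lean on, and the change in this assay is expected to be a number 2.5 percentage points higher from compound 1 to compound 3 (within the scatter), a movement not clearly beyond the usual scatter in either direction. On that basis compound 3 is estimated at 20% in this assay, with a range from 5% to 40%.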

Compound 3, a percentage reported as inhibition, at one concentration (the size of the read-out at that concentration, not a potency): 13.5%
Beside the measured number, compound 3's estimate is 6.5 percentage points above it; the range from low to high includes it.
By their numbers in this assay, from the lowest: compounds 3 and 1 (each within the scatter of the next); then compound 2.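

At the place on a nitrogen on an aromatic ring, 4-methoxy-3-methylphenyl in place of 4-(tert-butyl)phenyl gives a number 4 percentage points lower from compound 1 to compound 3 (within the scatter) in this assay, the first single-place step available in the series. On this read-out, at the one concentration tested, the exchange of an all-carbon group for one holding an oxygen and a hydrogen-bond acceptor does not separate compound 1 from compound 3. No measurement in hand speaks to why the two groups read alike or to any property of either group.

As far as these compounds go, whether a different group at this place, such as a 4-(dimethylamino)phenyl or a 4-carboxyphenyl, would move the number beyond the scatter stays open, as does the question of whether the shared core can give a much larger inhibition at this concentration in this assay at all. For the compounds shown here, no single-place step links compound 2 to compound 1 or compound 3, so the parts of compound 2 that differ from them cannot be read one by one.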